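The compounds below may be only part of what the source reports. "The series", "measured", "known", "first", "only" and "open" are said of these compounds alone.

Values from a functional assay on HeLa cells (Homo sapiens) for antiproliferative activity, read by sulforhodamine B assay, with a stated time of 48 h (on this read-out higher numbers stand for weaker inhibition of growth and lower numbers for stronger inhibition of growth), for the two compounds measured so far

- compound 1 (`COc1ccc([N+](=O)[O-])c(-c2nnc(C3=C(Cl)c4ccccc4CCC3)o2)c1OC`) gives 2830 nM
- compound 2 (`Cc1cc2c(cc1C)C(Cl)=C(c1nnc(-c3ccccc3)o1)CCC2`) gives 4680 nM

Compound 2 stands level with compound 1, as their two numbers lie within the usual scatter of each other. These two compounds differ in more than one place, so the data hold no measured single change to go by.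

Compound 3 (`Cc1cc2c(cc1C)C(Cl)=C(c1nnc(-c3ccc(F)cc3)o1)CCC2`) comes from compound 2 by one change, phenyl to 4-fluorophenyl, which puts fluoro in place of hydrogen on an aromatic carbon and leaves the rest of the structure as it was. With only compound 2 at 4680 nM as the starting point, no shift beyond the scatter is expected in this assay and no clear direction can be claimed. The expected 1.2-fold lower number from compound 2 to compound 3 (0.07 log units; within the scatter) is therefore small. The estimated value for compound 3 is 4000 nM with an expected range from 1800 nM to 9000 nM.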

Compound 3, concentration for 50% growth inhibition: 6420 nM
For compound 3 the middle estimate is 1.6-fold (0.21 log units) below the measured one, within the range that was stated.
By their numbers in this assay, from the lowest: compounds 1, 2 and 3 (each within the scatter of the next, the first and the last beyond it).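

For the compounds shown here, this is the first single change that can be read. In this assay, putting fluoro in place of hydrogen on the aromatic carbon para to a large group gives a 1.4-fold higher number from compound 2 to compound 3 (0.14 log units; within the scatter) and so leaves compound 3 level with compound 2. At this place on the phenyl ring, then, a single fluorine atom is accepted with no shift that stands out from the scatter, although this one step says nothing about other positions or other groups. Nothing available bears on why the two numbers stay level.

On these data alone, whether a larger or charged group at this same carbon, such as an amine or a carboxylic acid, would move the number beyond the scatter stays open. So does whether any change on the ring carrying the two methyl groups would matter.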